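Closing the Amide Nitrogen into a Methylpiperazine Ring

The source may hold more compounds than are shown below. What is called first, only, known or untested is meant among the compounds shown, and "the series" means these compounds.

Compound 1, `CCCCCCCCNC(=O)/C=C/c1c(/C=C/c2ccc(OC)cc2)cc(OC)cc1OC`, in a functional assay on MCF7 cells (Homo sapiens) for inhibition, read by MTT assay, with a stated time of 48 h (on this read-out higher numbers stand for weaker inhibition and lower numbers for stronger inhibition), gives 4280 nM.
Compound 2, `CCCCNC(=O)/C=C/c1c(/C=C/c2ccc(OC)cc2)cc(OC)cc1OC`, in this assay gives 1330 nM.
Compound 3, `CCC(C)NC(=O)/C=C/c1c(/C=C/c2ccc(OC)cc2)cc(OC)cc1OC`, in this assay gives 3430 nM.

For the measured compounds named here, compound 3 stands second highest of the three numbers: compound 1 lies close to it, within the scatter, while compound 2 gives the one clearly lower number, as a 2.6-fold higher number from compound 2 to compound 3 (0.41 log units; beyond the scatter) shows. The next step leads to compound 4, `COc1ccc(/C=C/c2cc(OC)cc(OC)c2/C=C/C(=O)N2CCN(C)CC2)cc1`, with the change (4-methylpiperazin-1-yl in place of (sec-butyl)amino on a carbonyl carbon). The measured steps altered only the chain on the amide nitrogen, and moved the number modestly (a 3.2-fold lower number from compound 1 to compound 2 (0.51 log units; beyond the scatter); a 1.2-fold lower number from compound 1 to compound 3 (0.10 log units; within the scatter)). Going by the values given here, none of them exchanges the amino group for a ring, so the change into compound 4 has no close precedent here. For compound 4 a step of similar or smaller size, in no firm direction, is expected. Compound 4 is therefore estimated at 3000 nM, between 800 nM and 12000 nM, which means an expected step of a 1.1-fold lower number from compound 3 to compound 4 (0.06 log units; within the scatter).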

Compound 4, half-maximal inhibitory concentration: 2290 nM
Beside the measured number, compound 4's estimate is 1.3-fold (0.12 log units) above it, and the stated range covers the measured number.
By their numbers in this assay, from the lowest: compounds 2, 4, 3 and 1 (each within the scatter of the next, the first and the last beyond it).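

Closing the nitrogen into a 4-methylpiperazin-1-yl ring removes the hydrogen-bond donor of the amide, yet in this assay every step stays within the scatter: a 1.5-fold lower number from compound 3 to compound 4 (0.18 log units; within the scatter), a 1.7-fold higher number from compound 2 to compound 4 (0.24 log units; within the scatter) and a 1.9-fold lower number from compound 1 to compound 4 (0.27 log units; within the scatter). So this carbonyl carbon accepts a ring as well as an open chain, and compound 4 sits within the scatter of compound 1, compound 2 and compound 3 alike. No measurement shown accounts for this result.

Still open, from the compounds shown here alone, is whether the second ring nitrogen matters, which a morpholin-4-yl group at this carbonyl carbon would test. A piperazin-1-yl group without the methyl would test the part played by that methyl.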